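A few compounds are considered here, and "the series" means these few. Any claim that something is new, unique, unknown or untested is made for them only; others in the source may bear on it.

Compound 1 `COc1cc(-c2ccnc3cc(-c4ccc(F)cc4)nn23)cc(OC)c1OC` carries a 4-fluorophenyl group on the shared core; in a functional assay on HCT-116 cells (Homo sapiens) for inhibition, read by CCK-8 assay, with a stated time of 48 h (on this read-out higher numbers stand for weaker inhibition and lower numbers for stronger inhibition), compound 1 gives 5030 nM. Compound 2 `COc1cc(-c2ccnc3cc(-c4cccc(C#N)c4)nn23)cc(OC)c1OC` reaches only the limit of this assay, > 10000 nM. Compound 3 `COc1cc(-c2ccnc3cc(-c4cn(C)c5ccccc45)nn23)cc(OC)c1OC` gives 762 nM. Of the two numbers shown, compound 1 stands highest. Compound 4 `COc1cc(-c2ccnc3cc(-c4ccc5ccn(C)c5c4)nn23)cc(OC)c1OC` differs from compound 1 by 1-methyl-1H-indol-6-yl in place of 4-fluorophenyl on an aromatic carbon. For the measured compounds named here, the step of a 6.6-fold lower number from compound 1 to compound 3 (0.82 log units; beyond the scatter) is the only measured step that replaces the 4-fluorophenyl with an indolyl group, and the step of an at least 1.9-fold higher number from compound 1 to compound 2 (0.29 log units; that floor lies within the scatter) ends at a limit. Going by the values given here, no measured step compares the two indolyl attachment points. Among the compounds with values here, a lowering for compound 4 is therefore expected, somewhat smaller than the one to compound 3: a 3.4-fold lower number from compound 1 to compound 4 (0.53 log units; beyond the scatter). Compound 4 is estimated at 1500 nM, with a range from 500 nM to 4500 nM.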

Compound 4, half-maximal inhibitory concentration: 1040 nM
For compound 4 the middle estimate is 1.4-fold (0.16 log units) above the measured one; the measured number falls inside the stated range.
By their numbers in this assay, from the lowest: compounds 3 and 4 (each within the scatter of the next); then compound 1. At a limit, above all of these: compound 2.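

In this assay, the gain over the 4-fluorophenyl group is not confined to one indolyl attachment point: a 4.8-fold lower number from compound 1 to compound 4 (0.68 log units; beyond the scatter), and a 1.4-fold higher number from compound 3 to compound 4 (0.14 log units; within the scatter), leaving the 1-methyl-1H-indol-6-yl and 1-methyl-1H-indol-3-yl groups indistinguishable here. Compound 2 stands at a limit of the assay rather than at a number, so an at least 9.6-fold lower number from compound 2 to compound 4 (0.98 log units; beyond the scatter) gives only a floor. Open questions include whether the methyl on the indole nitrogen matters, and how a quinoline or a morpholine would read at this position.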